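The compounds below may be only part of what the source reports. "The series", "measured", "known", "first", "only" and "open" are said of these compounds alone.

Measured compounds:
Compound 1 `COc1cc(-c2cc(/C=C/C(=O)c3ccc(N)cc3)[nH]n2)cc(OC)c1OC`, 8170 nM
Compound 2 `COc1ccc(-c2cc(/C=C/C(=O)c3ccc(N)cc3)[nH]n2)cc1OC`, 15000 nM
Compound 3 `COc1cc(C(=O)/C=C/c2cc(-c3cc(OC)c(OC)c(OC)c3)n[nH]2)cc(OC)c1OC`, 6130 nM

The three compounds share a trimethoxyphenyl-bearing chalcone-like arrangement attached to a pyrazole, and all were tested in a functional assay on M14 cells (Homo sapiens) for inhibition, read by sulforhodamine B assay, with a stated time of 48 h; on this read-out higher numbers stand for lower toxicity in this test and lower numbers for higher toxicity in this test. Compound 1 gives 8170 nM. Compound 2 gives 15000 nM. Compound 3 gives 6130 nM. Compound 2 differs from compound 1 by hydrogen in place of methoxy on an aromatic carbon, and this change gave a 1.8-fold higher number from compound 1 to compound 2 (0.26 log units; within the scatter). The cores of compound 1 and compound 3 differ in more than one place; the difference between the two cores is not broken down here. Compound 3 stands lowest of the three numbers, close to compound 1 and further from compound 2.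

Compound 4 `COc1ccc(-c2cc(/C=C/C(=O)c3cc(OC)c(OC)c(OC)c3)[nH]n2)cc1OC` has not yet been tested in this assay. It is obtained from compound 3 by hydrogen in place of methoxy on an aromatic carbon, the same change as that from compound 1 to compound 2, at the same kind of place. Since the earlier instance of this change stayed within the scatter, the step from compound 3 to compound 4 is expected to be of similar size, about a 1.7-fold higher number from compound 3 to compound 4 (0.23 log units; within the scatter), because a 1.8-fold higher number from compound 1 to compound 2 (0.26 log units; within the scatter) was seen before. On this basis compound 4 is estimated to give 10500 nM in this assay, with the range from 4500 nM to 24000 nM.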

Compound 4, concentration lethal to 50% of the cells: 7540 nM
Compound 4: the middle estimate sits 1.4-fold (0.14 log units) above what was measured; the range from low to high includes it.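

In this assay, putting hydrogen in place of methoxy on the core of compound 3 gave a 1.2-fold higher number from compound 3 to compound 4 (0.09 log units; within the scatter), so this instance of the change also stays inside the usual scatter. Set beside the earlier instance on the core of compound 1, the new step does not differ from it: the same change on two cores in this assay, a 1.8-fold higher number (0.26 log units; within the scatter) from compound 1 to compound 2 and a 1.2-fold higher number (0.09 log units; within the scatter) from compound 3 to compound 4, 1.5-fold (0.17 log units) apart, within the scatter of two such steps This shows that, across these two cores, the change carried over without any detectable dependence on the core, but it does not show that the change itself has a real effect on this read-out, since neither step lies beyond the scatter, and two pairs make no rule for other cores in the series.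

The compounds shown leave open whether a hydroxy group, a fluorine atom or a carboxylic acid in place of that methoxy group would give a step beyond the scatter. They also leave open what happens when further methoxy groups on the same ring give way to hydrogen, and whether a step of the same size would then appear on both cores.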